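The source may hold more compounds than are shown below. What is called first, only, known or untested is meant among the compounds shown, and "the series" means these compounds.

Compound 1 `CCC(C)C(=O)Nc1c(C(O)(C(F)(F)F)C(F)(F)F)ccc2ccccc12` gives 177000 nM in an assay on LtK cells with ATP-sensitive inward rectifier potassium channel 11 (Homo sapiens) as the target; on this read-out lower numbers stand for an effect already at smaller amounts and higher numbers for an effect only at larger amounts of compound.
Compound 2 `C/C=C/C(=O)Nc1c(C(O)(C(F)(F)F)C(F)(F)F)ccc2ccccc12` gives 72 nM in this assay.

Going by the values given here, compound 2 stands lowest of the two numbers so far; the only other number, from compound 1, is far higher, the step of a 2500-fold lower number from compound 1 to compound 2 (3.39 log units; beyond the scatter) lying well beyond the scatter. Compound 3 `O=C(Nc1c(C(O)(C(F)(F)F)C(F)(F)F)ccc2ccccc12)C1CCC1` differs from compound 2 in one place: cyclobutyl in place of prop-1-en-1-yl on a carbonyl carbon. Among the compounds with values here, the one measured step that bears on this change is a 2500-fold lower number from compound 1 to compound 2 (3.39 log units; beyond the scatter), where sec-butyl on the same carbonyl carbon gave a much higher number than prop-1-en-1-yl. Cyclobutyl, like sec-butyl, carries no double bond outside aromatic rings, but it brings a four-membered ring that neither measured compound contains, so the size of the step is uncertain. A large step toward a higher number is expected, estimated as a 280-fold higher number from compound 2 to compound 3 (2.44 log units; beyond the scatter). Compound 3 is expected to give about 20000 nM in this assay, within 2000 nM to 200000 nM.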

Compound 3, half-maximal effective concentration: 45 nM
The estimate for compound 3 lay 440-fold (2.65 log units) above the measured number, and the stated range ends above it.
By their numbers in this assay, from the lowest: compounds 3 and 2 (each within the scatter of the next); then compound 1.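

At the carbonyl carbon, the double bond of prop-1-en-1-yl proves unnecessary for a low number in this assay: cyclobutyl in its place gives a 1.6-fold lower number from compound 2 to compound 3 (0.20 log units; within the scatter) and so keeps the result within the scatter. Compound 3 has no double bond outside aromatic rings, yet cyclobutyl in place of sec-butyl gives a 3900-fold lower number from compound 1 to compound 3 (3.59 log units; beyond the scatter) and this shows that, among these three compounds, the high number of compound 1 does not follow from the lack of that double bond alone. Nothing available here accounts for the gap between sec-butyl and cyclobutyl.

Going by these compounds, it remains open whether cyclopentyl, isopropyl or a straight butyl chain on the same carbonyl carbon would fall with compounds 2 and 3 or with compound 1. On these data alone, how far a low number tolerates an amine or a carboxylic acid on this group also remains open.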